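Notes on the chloro-substituted core: varying the piperazine aryl

The source may hold more compounds than are shown below. What is called first, only, known or untested is meant among the compounds shown, and "the series" means these compounds.

Compound 1, `O=C1Nc2ccc(Cl)cc2/C1=N/NC(=S)N1CCN(c2ccccc2)CC1`, is the stronger of the two measured compounds in a functional assay on HCT-116 cells (Homo sapiens) for inhibition, read by MTT assay, with a stated time of 72 h (a higher number here means a weaker inhibitor, a lower number a stronger inhibitor), where compound 1 gives 3490 nM. Compound 2, `O=C1Nc2ccc([N+](=O)[O-])cc2/C1=N/NC(=S)N1CCN(c2ccccc2)CC1`, carries a nitro in place of chloro on an aromatic carbon of the shared core; in this assay compound 2 gives 15100 nM, and the step is a 4.3-fold higher number from compound 1 to compound 2 (0.64 log units; beyond the scatter).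

Compound 3, `O=C1Nc2ccc(Cl)cc2/C1=N/NC(=S)N1CCN(c2ccc(F)cc2F)CC1`, is not yet measured. It departs from compound 1 at a different place: 2,4-difluorophenyl in place of phenyl on an amine nitrogen in a ring. Within the data shown here, the only measured step concerns the substituent on the core aryl and says nothing about the aryl on the piperazine nitrogen, so no measured step bears on this change. With no guidance either way, the expected step of a 1.1-fold lower number from compound 1 to compound 3 (0.04 log units; within the scatter) is none beyond the scatter. Compound 3 is therefore estimated to give 3200 nM in this assay, with a range from 1100 nM to 9500 nM that is widened to reflect the absence of any comparable step among the measured compounds.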

Compound 3, half-maximal inhibitory concentration: 5890 nM
Compound 3: middle estimate off by 1.8-fold (0.26 log units), on the low side, and the stated range covers the measured number.
By their numbers in this assay, from the lowest: compounds 1 and 3 (each within the scatter of the next); then compound 2.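

In this assay, among these compounds, the first measured change at the aryl on an amine nitrogen in a ring, 2,4-difluorophenyl in place of phenyl, gives a 1.7-fold higher number from compound 1 to compound 3 (0.23 log units; within the scatter). Compound 1 and compound 3 therefore cannot be told apart in this assay, so this single aryl swap does not separate them, whereas the swap on the shared core, a 4.3-fold higher number from compound 1 to compound 2 (0.64 log units; beyond the scatter), lies beyond the scatter. No measurement at hand bears on the reason for this result at the aryl position.

Still open, from the compounds shown here alone, is whether the reading at this position holds for groups further from phenyl, such as a benzyl group, a pyridine ring or a phenyl carrying a methoxy group, since a single fluorine-bearing aryl cannot define the scope of the position. Also open, going by these compounds, is whether 2,4-difluorophenyl on the amine nitrogen behaves in the same way when the core carries the nitro of compound 2 rather than the chloro of compound 1.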